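Compound 4 and the metabolic stability of compound 2

A few compounds are considered here, and "the series" means these few. Any claim that something is new, unique, unknown or untested is made for them only; others in the source may bear on it.

- compound 1 `Cc1ccccc1S(=O)(=O)c1ccc(CNC(=O)c2cc3cnccc3[nH]2)cc1`: 48%
- compound 2 `O=C(NCc1ccc(S(=O)(=O)c2ccccc2)cc1)c1nc2cnccc2[nH]1`: 73%
- compound 3 `O=C(NCc1ccc(S(=O)(=O)N2CCCCC2)cc1)c1cc2ccncc2[nH]1`: 50%

In an ADME assay on microsomes from liver (Homo sapiens) for metabolic stability, read by LC-MS, with a stated time of 30 min, tested at 1 uM (on this read-out higher numbers stand for a more stable compound and lower numbers for a less stable compound), compound 2 gives 73%, the highest of the three numbers, and the values of the other two compounds lie beyond the scatter from it. The next compound to be tested is compound 4 `O=C(NCc1ccc(S(=O)(=O)c2ccccc2)cc1)c1c[nH]c2ccncc12`, which keeps the rest of compound 2 and exchanges one group on a carbonyl carbon: a group of 9 heavy atoms (7 carbon, 2 nitrogen; one five-membered aromatic ring with 1 hetero atom, one six-membered aromatic ring with 1 hetero atom) in place of a group of 9 heavy atoms (6 carbon, 3 nitrogen; one five-membered aromatic ring with 2 hetero atoms, one six-membered aromatic ring with 1 hetero atom), on a carbonyl carbon.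

Going by the values given here, no measured pair isolates a change of this kind, so the expectation rests on little. Compound 1 at 48% and compound 3 at 50% are the only other reference points, and compound 2 at 73% stands alone at the top. A fall toward those numbers therefore seems more likely than a further rise, though a step within the scatter remains possible. The expected change is a moderate loss, estimated as a number 15 percentage points lower from compound 2 to compound 4 (beyond the scatter). For compound 4 the estimate is 58%, with an expected range from 38% to 78%.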

Compound 4, percent of the compound remaining: > 99%
Compound 4 was reported as a limit; the forecaster's own chance of this, stated with the estimate: 2%; middle value at least 41 percentage points away from the limit.
By their numbers in this assay, from the lowest: compounds 1 and 3 (each within the scatter of the next); then compound 2. At a limit, above all of these: compound 4.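

In this assay compound 4 gives > 99%, which is a limit of the assay and not a number. With the rest of compound 2 kept, the group with one five-membered aromatic ring with 1 hetero atom, placed on the carbonyl carbon instead of the group whose five-membered aromatic ring has 2 hetero atoms, gives a number at least 26 percentage points higher from compound 2 to compound 4 (beyond the scatter), so this position clearly matters in this assay. The earlier compounds differ from one another in more than one place and could not show this, and the step is bounded on one side only: the limit of > 99% in this assay, at which 1 of the 4 values shown sits.

The compounds shown leave open whether a fluorine, a methyl or an amine on the entering group would keep this result. They also leave open whether the same exchange would carry over to a compound with a different sulfonyl part.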